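A Methoxybenzyl Group Replaces a Fluorinated Ether Chain

The compounds below may be only part of what the source reports. "The series", "measured", "known", "first", "only" and "open" are said of these compounds alone.

Of the compounds shown here, three built on a shared core have been measured in an assay on membranes from brain for displacement of a labelled ligand from Sigma non-opioid intracellular receptor 1 (Cavia porcellus), read by scintillation counting, with a stated time of 90 min; a higher number here means a weaker inhibitor, a lower number a stronger inhibitor. Compound 1 `COc1cc2c(cc1OC)CN(CCCCNC(=O)c1cn(Cc3cccc(O)c3)nn1)CC2` gives 8080 nM. Compound 2 `COc1cc2c(cc1OC)CN(CCCCNC(=O)c1ccc(-c3cn(CCOCCF)nn3)cc1)CC2` gives 14700 nM, and compound 3 `COc1cc2c(cc1OC)CN(CCCCNC(=O)c1ccc(-c3cn(CCOCCOCCF)nn3)cc1)CC2` gives 16000 nM. Compound 3 stands at the highest number of the three, but its gap to compound 2 is within the scatter, and so is its gap to compound 1. Going by the values given here, the only step that can be read directly, a 1.1-fold higher number from compound 2 to compound 3 (0.04 log units; within the scatter), lies within the scatter as well.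

Compound 4 `COc1ccc(Cn2cc(-c3ccc(C(=O)NCCCCN4CCc5cc(OC)c(OC)cc5C4)cc3)nn2)cc1` differs from compound 3 in one place: 4-methoxyphenyl in place of (2-(2-fluoroethoxy)ethoxy)methyl on a saturated chain carbon bound to an aromatic nitrogen. Among the compounds with values here, no measured step bears on this change, and the step from compound 2 to compound 3 shows only that lengthening the chain left the number where it was. Compound 1, which carries an aromatic ring on the corresponding carbon of a shorter core, sits at a lower number than compound 3, though still within the scatter. On this thin footing, compound 4 is expected to come in at a modestly lower number, an estimated 2.0-fold lower number from compound 3 to compound 4 (0.30 log units; within the scatter), giving a value of about 8000 nM with a range from 3000 nM to 25000 nM.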

Compound 4, inhibition constant: 12600 nM
The estimate for compound 4 lay 1.6-fold (0.20 log units) below the measured number, within the range that was stated.
By their numbers in this assay, from the lowest: compounds 1, 4, 2 and 3 (each within the scatter of the next).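

In this assay, the 4-methoxyphenyl group in place of (2-(2-fluoroethoxy)ethoxy)methyl gives a 1.3-fold lower number from compound 3 to compound 4 (0.10 log units; within the scatter), and in place of (2-fluoroethoxy)methyl it gives a 1.2-fold lower number from compound 2 to compound 4 (0.07 log units; within the scatter). At this place, on a saturated chain carbon bound to an aromatic nitrogen, a six-membered aromatic ring of carbon only can therefore stand in for a chain with no ring without moving the number beyond the scatter, which the earlier step, a change of chain length alone, could not show. No measurement is at hand that would explain this result.

On these data alone, whether any group at this place can move the number beyond the scatter remains open. An amine or a carboxylic acid in place of the methoxy group on the ring would be one test of that.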